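The source may report more compounds than this note shows. Statements on the series, on what has been measured and on what is new or still open speak of the compounds shown alone.

Measured so far in a functional assay on Col2 cells (Homo sapiens) for cytotoxicity; a lower number here means that less compound is needed, a higher number that more compound is needed for the effect:
compound 1 `CCCCCCCCO[C@@H]1O[C@@H](C)[C@H](OC(=O)CCCCC)[C@@H](O[C@@H]2O[C@@H](C)[C@H](OC(C)=O)[C@@H](O[C@@H]3O[C@@H](C)[C@H](OC(C)=O)[C@@H](OC(C)=O)[C@H]3O)[C@H]2OC(C)=O)[C@H]1O` gives 4.9 ug/mL
compound 2 `CCCCCCCCO[C@@H]1O[C@@H](C)[C@H](OC(=O)CCCCC)[C@@H](O[C@@H]2O[C@@H](C)[C@H](OC(C)=O)[C@@H](OC(C)=O)[C@H]2OC(C)=O)[C@H]1O` gives 9 ug/mL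

Compound 1 has the lower of the two numbers, but compound 2 lies within the scatter of it, so the two cannot be ordered. Compound 3 `CCCCCCCCO[C@@H]1O[C@@H](C)[C@H](OC(=O)CCCCC)[C@@H](O[C@@H]2O[C@@H](C)[C@H](OC(C)=O)[C@@H](O[C@@H]3O[C@@H](C)[C@H](OC(C)=O)[C@@H](O)[C@H]3O)[C@H]2OC(C)=O)[C@H]1O` differs from compound 1 by hydrogen in place of acetyl on an oxygen on a saturated carbon. Among the measured compounds shown here, no step of this kind has been measured, so there is no basis for expecting a large shift in this assay in either direction; the expected step of a 1.2-fold higher number from compound 1 to compound 3 (0.09 log units; within the scatter) is within the scatter. Compound 3 is estimated at 6 ug/mL, with a range of 2.5 ug/mL to 14 ug/mL.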

Compound 3, concentration for half-maximal effect: 6.2 ug/mL
For compound 3 the middle estimate is 1.0-fold (0.01 log units) below the measured one; low and high end bracket the measured number.
By their numbers in this assay, from the lowest: compounds 1, 3 and 2 (each within the scatter of the next).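

In this assay hydrogen in place of acetyl on this oxygen gives a 1.3-fold higher number from compound 1 to compound 3 (0.10 log units; within the scatter). Among the compounds shown here, this is the first reading of this change: at this position, acetoxy to hydroxy produces no shift beyond the scatter. No supporting measurement bears on this result.

Still open, as far as these compounds go, is how an amine or a methyl ether would read at this position. Also open, from the compounds shown here alone, is whether acetoxy to hydroxy at the other acetylated oxygens of compound 1 would read the same way in this assay here.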